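The compounds below may be only part of what the source reports. "The series", "measured", "known", "first", "only" and "open" are said of these compounds alone.

Measured so far:
compound 1 `CCNC(=O)Nc1nc2cc(-c3cnc(N4CCC(C)(C(=O)O)CC4)nc3)cc(-c3ccccn3)c2s1` — in a physicochemical assay for solubility, read by turbidimetry, in phosphate buffer, with a stated time of 24 h, at pH 7.4 (on this read-out lower numbers stand for lower solubility and higher numbers for higher solubility), compound 1 gives > 800 ug/mL, a limit of the read-out rather than a number.
compound 2 `CCNC(=O)Nc1nc2cc(-c3cnc(N4CCC(CC)(C(=O)O)CC4)nc3)cc(-c3ccccn3)c2s1` — in this assay compound 2 gives > 800 ug/mL, again a limit and not a number.

Compound 2 thus stands at the upper limit of this assay; nothing finer is known about it. Among the compounds with values here, the one measured step, a step that the two limits leave unreadable from compound 1 to compound 2, cannot be sized, since (the limit of > 800 ug/mL in this assay, at which 2 of the 2 values shown sit).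

Compound 3 `CCNC(=O)Nc1nc2cc(-c3cnc(N4CCCC4(C)C(=O)O)nc3)cc(-c3ccccn3)c2s1` differs from compound 2 in one place: 2-carboxy-2-methylpyrrolidin-1-yl in place of 4-carboxy-4-ethylpiperidin-1-yl on an aromatic carbon. The carboxylic acid is kept; the saturated ring shrinks by the count given there and the ethyl gives way to methyl. Within the data shown here, no measured step reports a readable change in this assay for this series; the only step available, from compound 1 to compound 2, was unreadable, so no step beyond the scatter is expected here either, and the value is expected to stay at the limit.

The estimated step that the limit leaves unreadable from compound 2 to compound 3 is expected to be none beyond the scatter. Compound 3 is expected at 1000 ug/mL, with a range from 500 ug/mL to 2000 ug/mL.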

Compound 3, solubility: > 800 ug/mL
Compound 3: only a limit was reported; the forecaster's own chance of this, stated with the estimate: 80%; the middle value is on the limit's open side.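

No new step can be read in this assay from compound 3 set against compound 2 or compound 1, and all of these steps stay unreadable: the limit of > 800 ug/mL in this assay, at which 3 of the 3 values shown sit.

The compounds shown leave open whether compound 1, compound 2 and compound 3 differ at all on this read-out, and which change to the carboxylic acid-bearing ring, if any, would give a readable number.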